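Cyclic urea replaces imidazolylmethyl on the shared core

A few compounds are considered here, and "the series" means these few. Any claim that something is new, unique, unknown or untested is made for them only; others in the source may bear on it.

Three compounds sharing the core of compound 1 `CC(C)C(c1nnc[nH]1)c1ccc(-c2ccc3cccc(F)c3c2)[nH]c1=O` have been tested in a functional assay on CHO cells for antagonist activity at prostaglandin E2 receptor EP3 subtype (Homo sapiens), read by cAMP accumulation; a lower number here means a stronger inhibitor, a higher number a weaker inhibitor. Compound 1 gives 21 nM, compound 2 `CC(C)NC(=O)CC(c1ccc(-c2ccc3cccc(F)c3c2)[nH]c1=O)C(C)C` gives 15 nM, and compound 3 `CC(C)C(Cc1ncc[nH]1)c1ccc(-c2ccc3cccc(F)c3c2)[nH]c1=O` gives 76 nM. Compound 3 stands highest of the three: the step of a 3.6-fold higher number from compound 1 to compound 3 (0.56 log units; beyond the scatter) and the step of a 5.1-fold higher number from compound 2 to compound 3 (0.70 log units; beyond the scatter) both run beyond the scatter, whereas the step of a 1.4-fold lower number from compound 1 to compound 2 (0.15 log units; within the scatter) does not.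

Compound 4 `CC(C)C(c1ccc(-c2ccc3cccc(F)c3c2)[nH]c1=O)N1CCNC1=O` is not yet measured. The change from compound 3 is 2-oxoimidazolidin-1-yl in place of (1H-imidazol-2-yl)methyl on a saturated chain carbon bound to an aromatic carbon and a saturated chain carbon. The step from compound 1 to compound 3 bears on it, since a five-membered ring held directly on the chain carbon is again present in compound 4; the step from compound 2 to compound 3 also bears on it, since a carbonyl-bearing group returns. Both point to a lower number in this assay for compound 4 than for compound 3, and the expected step is a 3.0-fold lower number from compound 3 to compound 4 (0.48 log units; beyond the scatter). Compound 4 is therefore estimated at 25 nM, with a range from 8 nM to 80 nM.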

Compound 4, half-maximal inhibitory concentration in the prostaglandin E2 receptor EP3 subtype assay: 28 nM
For compound 4 the middle estimate is 1.1-fold (0.05 log units) below the measured one; low and high end bracket the measured number.
By their numbers in the prostaglandin E2 receptor EP3 subtype assay, from the lowest: compounds 2, 1 and 4 (each within the scatter of the next); then compound 3.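

In the prostaglandin E2 receptor EP3 subtype assay the 2-oxoimidazolidin-1-yl group, a five-membered non-aromatic ring on the saturated chain carbon, gives a 2.7-fold lower number from compound 3 to compound 4 (0.43 log units; beyond the scatter) and so shows that an aromatic ring in this group is not needed for the lower numbers of the series. In the prostaglandin E2 receptor EP3 subtype assay the steps of a 1.9-fold higher number from compound 2 to compound 4 (0.27 log units; within the scatter) and a 1.3-fold higher number from compound 1 to compound 4 (0.12 log units; within the scatter) both lie within the scatter, so only compound 3 stands apart among the four. In a physicochemical assay for solubility, measured as kinetic solubility, at pH 2 (on this read-out higher numbers stand for higher solubility and lower numbers for lower solubility), compound 3 gives 33800 nM and compound 4 gives 31600 nM with a 1.1-fold lower number from compound 3 to compound 4 (0.03 log units; within the scatter) so this read-out does not separate them.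

Whether an amine or a carboxylic acid at this place would keep the number in the prostaglandin E2 receptor EP3 subtype assay stays open, and no measured evidence explains why compound 3 stands apart.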